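This account rests on a few compounds, and the source may have more. Where it says the series, first, only, none or still open, it means among the compounds named here.

Measured so far:
compound 2 `Cc1ccc(C(=O)Nc2cccc(NC(=O)COc3ccc4c(=O)ccoc4c3)c2)cc1`: 22 nM
compound 1 `COc1cccc(OCC(=O)Nc2cccc(NC(=O)c3ccc(N(C)C)cc3)c2)c1`: 5740 nM

Among the measured compounds shown here, in an assay on isolated protein for inhibition of Rho-associated protein kinase 2 (Homo sapiens), read by scintillation counting, radiometric assay and 33P incorporation, with a stated time of 40 min, in the presence of a further agent that is not named here (a higher number here means a weaker inhibitor, a lower number a stronger inhibitor), compound 2 gives the lowest of the two numbers so far, and the nearest neighbour, compound 1, sits a long way above it, well beyond the scatter of repeated runs. Compound 3 `Cn1ccc(S(=O)(=O)Nc2cccc(NC(=O)COc3ccc4c(=O)ccoc4c3)c2)n1` is the next compound to be measured. It differs from compound 2 in one place: a group of 9 heavy atoms (4 carbon, 2 nitrogen, 2 oxygen, 1 sulfur; one five-membered aromatic ring with 2 hetero atoms) in place of a group of 9 heavy atoms (8 carbon, 1 oxygen; one six-membered aromatic ring of carbon only), on a nitrogen on an aromatic ring. The change replaces a carbon-only aromatic ring with a hetero-aromatic one and introduces a sulfur-bearing linker in place of the carbonyl, so the connection on that nitrogen is no longer an amide. For the measured compounds named here, there is no measured pair that isolates this kind of exchange, so the direction must be a guess; the account expects the number for compound 3 to rise, with a step of a 16-fold higher number from compound 2 to compound 3 (1.20 log units; beyond the scatter) that goes beyond the scatter. The estimated value for compound 3 in this assay is 350 nM, with a range from 50 nM to 3000 nM.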

Compound 3, half-maximal inhibitory concentration: 1350 nM
Compound 3: the middle estimate sits 3.9-fold (0.59 log units) below what was measured, and the stated range covers the measured number.
By their numbers in this assay, from the lowest: compound 2; then compound 3; then compound 1.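

In this assay, the group on this nitrogen turns out to matter a great deal: with the rest of the molecule unchanged, replacing the (4-methylphenyl)carbonyl with the sulfur-bearing group and its five-membered aromatic ring gives a large loss of inhibition, a step of a 61-fold higher number from compound 2 to compound 3 (1.79 log units; beyond the scatter). Among the compounds shown here, this is the first measured pair that isolates this position, and the two groups differ sharply in effect even though both hold 9 heavy atoms and carry no net charge. No measurement at hand explains the rise.

The exchange alters both the ring and the link to the nitrogen, so these compounds cannot show which of the two accounts for the step. From the compounds shown here alone, a (4-methylphenyl)sulfonyl group, or a carbonyl bearing the same five-membered ring, would separate the two, and how either would read here remains open.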